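The source may hold more compounds than are shown below. What is called first, only, known or untested is meant among the compounds shown, and "the series" means these compounds.

Measured compounds in the series:

compound 1, `CC(=O)N1N=C(Nc2nc3ccccc3s2)CC1c1ccccc1`, 315 umol/kg
compound 2, `CC(=O)N1N=C(Nc2nc3ccccc3s2)CC1c1ccc(Cl)cc1`, 209 umol/kg
compound 3, `COc1ccc(/C=C/C(=O)Nc2nc3ccccc3s2)cc1O`, 495 umol/kg

All three values come from a functional assay on the whole organism (Hindlimb, strain albino) with Mus musculus as the target, in the maximal electroshock model, with a stated time of 0.5 h; a lower number here means that less compound is needed, a higher number that more compound is needed for the effect. Compound 1 and compound 2 share a core and differ only by chloro in place of hydrogen on an aromatic carbon; that step is a 1.5-fold lower number from compound 1 to compound 2 (0.18 log units; within the scatter). Compound 3 carries a different core, and the difference between the two cores is not broken down here. Compound 3 and compound 2 differ beyond the scatter, while compound 3 and compound 1 lie within it.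

Compound 4, `COc1ccc(/C=C/C(=O)Nc2nc3ccc(Cl)cc3s2)cc1O`, is not yet measured. It differs from compound 3 by chloro in place of hydrogen on an aromatic carbon. This is the same kind of change as that from compound 1 to compound 2, but the place differs: in compound 2 the chloro stands on a ring para to a large group, while in compound 4 it stands on a ring that is part of a fused system of two rings, meta to a fused ring and para to a fused ring.

Within the data shown here, from compound 3 to compound 4 a step of a 1.2-fold lower number from compound 3 to compound 4 (0.09 log units; within the scatter) is expected, resting on the single earlier step of a 1.5-fold lower number from compound 1 to compound 2 (0.18 log units; within the scatter), which stays within the scatter. Compound 4 is thus estimated at 400 umol/kg, with a range from 200 umol/kg to 800 umol/kg.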

Compound 4, dose for half-maximal effect: 320 umol/kg
The estimate for compound 4 lay 1.3-fold (0.10 log units) above the measured number; the measured number falls inside the stated range.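

In this assay, chloro in place of hydrogen on an aromatic carbon gives a 1.5-fold lower number from compound 3 to compound 4 (0.19 log units; within the scatter), and the earlier step on the other core agrees with it: the same change on two cores in this assay, a 1.5-fold lower number (0.18 log units; within the scatter) from compound 1 to compound 2 and a 1.5-fold lower number (0.19 log units; within the scatter) from compound 3 to compound 4, 1.0-fold (0.01 log units) apart, within the scatter of two such steps. The change therefore reads alike on two cores, including at a place on a ring that is part of a fused system of two rings. Both steps lie within the scatter, so the pair shows no effect of chloro that stands clear of repeat measurement and says nothing about a third core.

Open, from the compounds shown here alone, is whether fluoro, nitro or an amine at the same place would give a step beyond the scatter. Also open, going by these compounds, is how chloro reads at other places on these cores.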